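Removing the fluoro group: what the next compound may show

The compounds below may be only part of what the source reports. "The series", "measured", "known", "first", "only" and "open" are said of these compounds alone.

Measured so far:
- compound 1, `CCOc1ccc(NC2=CC(=O)c3ncncc3C2=O)cc1` — in a functional assay on SK-MEL-2 cells (Homo sapiens) for cytotoxicity, read by MTT assay, with a stated time of 72 h (on this read-out lower numbers stand for stronger inhibition and higher numbers for weaker inhibition), compound 1 gives 0.02 ug/mL
- compound 2, `O=C1C(Nc2ccc(F)cc2)=CC(=O)c2ncncc21` — in this assay compound 2 gives 0.05 ug/mL

Among the two numbers, compound 2 stands highest; its nearest neighbour is compound 1, and the only measured step, a 2.5-fold higher number from compound 1 to compound 2 (0.40 log units; beyond the scatter), separates them. That step swapped one group for another on the aromatic ring that carries the amine.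

The unmeasured compound 3, `O=C1C(Nc2ccccc2)=CC(=O)c2ncncc21`, differs from compound 2 by hydrogen in place of fluoro on an aromatic carbon. Going by the values given here, no measured step removes a group in this way; the one known step, a 2.5-fold higher number from compound 1 to compound 2 (0.40 log units; beyond the scatter), only shows that changing this position shifted the number by a modest amount. It therefore bears on compound 3 only loosely, and the direction is uncertain. Since both measured compounds lie close together, the expectation for compound 3 in this assay is a number near that of compound 2, with a step of a 1.2-fold higher number from compound 2 to compound 3 (0.08 log units; within the scatter) expected. The estimate for compound 3 is 0.06 ug/mL, with a range from 0.02 ug/mL to 0.2 ug/mL.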

Compound 3, half-maximal inhibitory concentration: 0.01 ug/mL
Compound 3: the middle estimate sits 6.0-fold (0.78 log units) above what was measured, outside the stated range (below it).
By their numbers in this assay, from the lowest: compounds 3 and 1 (each within the scatter of the next); then compound 2.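

Until now this position had only been seen with one group swapped for another. Replacing the fluoro group on this aromatic carbon, para to a large group, with plain hydrogen in this assay gives a 5.0-fold lower number from compound 2 to compound 3 (0.70 log units; beyond the scatter) and shows that the ring needs no group here at all to reach a low number. Hydrogen in place of ethoxy gives a 2.0-fold lower number from compound 1 to compound 3 (0.30 log units; within the scatter) and so leaves the bare ring and the ethoxy-bearing ring indistinguishable on these numbers, which makes compound 2, the fluoro compound, the one that stands apart from the other two, and no measurement shown here explains that difference.

From the compounds shown here alone, it remains open whether this higher number belongs to fluoro alone or would also appear with another small group on the same carbon, such as chloro, methyl or an amine, any of which might fall with compound 2 or with the other two. A longer chain than ethoxy, or a carboxylic acid, at this carbon is equally uncharted, so how much room this position allows before the number rises cannot yet be told.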